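The source may hold more compounds than are shown below. What is called first, only, known or untested is meant among the compounds shown, and "the series" means these compounds.

Measured in an ADME assay on microsomes from liver (Mus musculus) for metabolic stability; on this read-out lower numbers stand for slow clearance and higher numbers for fast clearance:
Compound 1 `O=C(O)Cn1nc(Cc2nc3cc(Cl)c(OCC(F)F)cc3[nH]2)c2ccccc2c1=O`: < 56.7 mL/min/kg, a limit of the assay rather than a number.
Compound 2 `CCOc1cc2[nH]c(Cc3nn(CC(=O)N4CCOCC4)c(=O)c4ccccc34)nc2cc1Cl`: 817 mL/min/kg.
Compound 3 `O=C(O)Cn1nc(Cc2nc3cc(Cl)c(OCC4CC4)cc3[nH]2)c2ccccc2c1=O`: 147 mL/min/kg.

Compound 3 gives the lower of the two numbers in this assay, compound 2 the higher. Compound 1 sits at the limit of < 56.7 mL/min/kg in this assay, at which 1 of the 3 values shown sits. For the measured compounds named here, the single measured step, an at least 2.5-fold higher number from compound 1 to compound 3 (0.41 log units; beyond the scatter), concerns the same ether chain. Compound 4 `CCOc1cc2[nH]c(Cc3nn(CC(=O)O)c(=O)c4ccccc34)nc2cc1Cl` differs from compound 3 by methyl in place of cyclopropyl on a saturated chain carbon bound to an oxygen on an aromatic ring. That measured step went from difluoromethyl to cyclopropyl and raised the number; removing the cyclopropyl for methyl is taken to lower the number of compound 3 somewhat, or leave it within the scatter. Compound 4 is therefore expected to show a 1.5-fold lower number from compound 3 to compound 4 (0.17 log units; within the scatter). The estimate for compound 4 is 100 mL/min/kg, with a range from 40 mL/min/kg to 250 mL/min/kg.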

Compound 4, clearance in the Mus musculus assay: < 51.7 mL/min/kg
Compound 4 was reported as a limit; the forecaster's own chance of this, stated with the estimate: 20%; at least 1.9-fold (0.28 log units) between middle value and limit.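

In the Mus musculus assay, the change from cyclopropylmethoxy to ethoxy gives an at least 2.8-fold lower number from compound 3 to compound 4 (0.45 log units; beyond the scatter), so this ether chain also moves clearance when ethoxy, rather than difluoroethoxy, is the group compared with cyclopropylmethoxy. On the ethoxy series, the Mus musculus assay shows a separate effect at the carbonyl carbon, with hydroxy in place of morpholin-4-yl giving an at least 15-fold lower number from compound 2 to compound 4 (1.19 log units; beyond the scatter). In a physicochemical assay for lipophilicity, at pH 7.4 (on this read-out lower numbers stand for lower lipophilicity and higher numbers for higher lipophilicity), compound 3 gives 2.21 and compound 4 gives 1.8, so distribution coefficient and clearance fall together in this one pair.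

Compound 1 and compound 4 are both limits of the assay, so the step between them cannot be read. On these data alone, how a longer chain such as propoxy, or an amine on the ether chain, would read remains open.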